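The source may hold more compounds than are shown below. What is called first, only, known or untested is meant among the compounds shown, and "the series" means these compounds.

Measured so far:
Compound 1, `Cn1c(-c2ccc(NC(=O)CSc3nc4ccccc4o3)cc2)nc(-c2ccccc2)c1-c1ccccc1`: 44.9%
Compound 2, `Cc1ccc2oc(SCC(=O)Nc3ccc(-c4nc(-c5ccccc5)c(-c5ccccc5)n4C)cc3)nc2c1`: 25.6%
Compound 3, `Cn1c(-c2ccc(NC(=O)CN3CCN(Cc4ccccc4)CC3)cc2)nc(-c2ccccc2)c1-c1ccccc1`: 26.8%

All three were tested in a functional assay on HT-29 cells (Homo sapiens) for cytotoxicity, read by MTT assay, with a stated time of 24 h, tested at 6.4 ug/mL; a higher number here means a stronger effect of the compound at the concentration tested, a lower number a weaker effect. Compound 1 and compound 2 differ by methyl in place of hydrogen on an aromatic carbon, and this gave a number 19.3 percentage points lower from compound 1 to compound 2 (beyond the scatter). Compound 3 carries a different side chain; how its core differs from the core of compound 1 is not broken down here. In this assay compound 3 gives 26.8%, and compound 2 gives 25.6%, the two lying within the usual scatter of each other.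

Compound 4, `Cc1ccc(CN2CCN(CC(=O)Nc3ccc(-c4nc(-c5ccccc5)c(-c5ccccc5)n4C)cc3)CC2)cc1`, is not yet measured. It differs from compound 3 by methyl in place of hydrogen on an aromatic carbon. This is the same kind of change as from compound 1 to compound 2, but the surroundings differ: there the methyl entered a ring that is part of a fused or bridged system of two rings, meta to a fused ring and para to a fused ring, whereas here it enters a six-membered aromatic ring of carbon only, para to a large group. A step of a number 7.8 percentage points lower from compound 3 to compound 4 (within the scatter) is expected, smaller than the earlier one. This rests on a single precedent, a number 19.3 percentage points lower from compound 1 to compound 2 (beyond the scatter), made in a different part of the molecule, and on compound 3 already giving a low 26.8%. Compound 4 is therefore estimated to give 19%, with a likely range from 5% to 34%.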

Compound 4, a percentage reported as activity, at one concentration (the size of the read-out at that concentration, not a potency): 27.7%
The estimate for compound 4 lay 8.7 percentage points below the measured number, within the range that was stated.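

In this assay, methyl in place of hydrogen on an aromatic carbon, which turns benzyl into 4-methylbenzyl, gave a number 0.9 percentage points higher from compound 3 to compound 4 (within the scatter), so this step shows no real change. Set beside the earlier case, the same kind of change did not give the same result in the two settings: the same change on two cores in this assay, a number 19.3 percentage points lower (beyond the scatter) from compound 1 to compound 2 and a number 0.9 percentage points higher (within the scatter) from compound 3 to compound 4, 20.2 percentage points apart, beyond the scatter of two such steps This shows that the result of adding this methyl in one compound pair cannot simply be carried over to another in this series, but it does not show why the two steps differ, as the methyl enters a different ring in each pair and two steps say nothing about a third core.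

The compounds shown leave open whether a group other than methyl on this ring, such as a chlorine atom or a methoxy group, would move the number beyond the scatter. Also open, from the compounds shown here alone, is what a longer chain, such as ethyl, would do in the same place.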